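Bromophenyl amide on the benzyl-bearing core: compound 4

The source may report more compounds than this note shows. Statements on the series, on what has been measured and on what is new or still open speak of the compounds shown alone.

Measured in a functional assay on A549 cells (Homo sapiens) for cytotoxicity, read by MTT assay, with a stated time of 72 h; on this read-out higher numbers stand for weaker inhibition and lower numbers for stronger inhibition:
compound 1 `Cc1cccc(Cl)c1NC(=O)CN1CCN(c2nnc(Cc3ccncc3)c3ccccc23)CC1` gives 7190 nM
compound 2 `COc1ccc(NC(=O)CN2CCN(c3nnc(Cc4ccccc4)c4ccccc34)CC2)cc1OC` gives "not active" (no number reported)
compound 3 `O=C(CN1CCN(c2nnc(Cc3ccncc3)c3ccccc23)CC1)Nc1cccc(Br)c1` gives 1530 nM

Compound 2 stands with no number in this assay, reported only as not active. Compound 4 `O=C(CN1CCN(c2nnc(Cc3ccccc3)c3ccccc23)CC1)Nc1ccc(Br)cc1` is drawn from it by the change (4-bromophenyl in place of 3,4-dimethoxyphenyl on an amide-type nitrogen). Within the data shown here, the only measured step at the same position is a 4.7-fold lower number from compound 1 to compound 3 (0.67 log units; beyond the scatter), which shows a bromophenyl amide on the shared core giving a modest gain, though that pair carries a different core from compound 2 and compound 4, and no step links the two cores. Compound 2 offers no number to build from, so the expectation for compound 4 rests on compound 3 and its value 1530 nM widened for the core difference. Compound 4 is therefore estimated at 5000 nM, with a range of 1200 nM to 30000 nM.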

Compound 4, half-maximal inhibitory concentration: 2000 nM
For compound 4 the middle estimate is 2.5-fold (0.40 log units) above the measured one; the measured number falls inside the stated range.
By their numbers in this assay, from the lowest: compounds 3 and 4 (each within the scatter of the next); then compound 1.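

Among these compounds, compound 2 is reported only as not active, so no step to compound 4 can be read. The compounds shown leave open what the core alone contributes, with compound 3 and compound 4 differing in more than one place. No measured evidence bears on a cause for this result.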